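From a methoxy-bearing ring to a difluoro ring

The compounds below may be only part of what the source reports. "The series", "measured", "known", "first", "only" and "open" are said of these compounds alone.

Two related compounds have been tested so far. Compound 1 `COc1ccc(C(=O)/C=C/c2cc(-c3cc(OC)c(OC)c(OC)c3)n[nH]2)cc1OC` and compound 2 `COc1ccc(C(=O)/C=C/c2cc(-c3cc(OC)c(OC)c(OC)c3)n[nH]2)cc1` share one core and differ only in that hydrogen replaces a methoxy on an aromatic carbon. In a functional assay on SW-620 cells (Homo sapiens) for cytotoxicity, read by sulforhodamine B assay, with a stated time of 48 h, tested at 10 uM (on this read-out higher numbers stand for a weaker effect at the one concentration tested and lower numbers for a stronger effect), compound 1 gives -77%, and compound 2 gives -69%. The step of a number 8 percentage points higher from compound 1 to compound 2 (within the scatter) lies within the usual scatter, so the two numbers cannot be told apart, and compound 2 stands next to compound 1 without a real gap between them.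

The next compound, compound 3 `COc1cc(-c2cc(/C=C/C(=O)c3ccc(F)c(F)c3)[nH]n2)cc(OC)c1OC`, changes a different part of the molecule: 3,4-difluorophenyl in place of 4-methoxyphenyl on a carbonyl carbon. Going by the values given here, no measured step touches this end of the structure, so the only guidance is that the one step seen so far stayed within the scatter. With no evidence either way, the expectation is that compound 3 lands near compound 2, but with a wider range to reflect the lack of a comparable measurement. For compound 3 the expected value is -60%, estimated to fall between -85% and -30%. This would correspond to an expected step of a number 9 percentage points higher from compound 2 to compound 3 (within the scatter), which is not expected to exceed the scatter.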

Compound 3, a percentage reported as activity, at one concentration (the size of the read-out at that concentration, not a potency): 12%
Compound 3: middle estimate off by 72 percentage points, on the low side; the whole stated range lies below it.
By their numbers in this assay, from the lowest: compounds 1 and 2 (each within the scatter of the next); then compound 3.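

In this assay the group on the carbonyl carbon proves far from neutral: 3,4-difluorophenyl in place of 4-methoxyphenyl gives a number 81 percentage points higher from compound 2 to compound 3 (beyond the scatter) and 3,4-difluorophenyl in place of 3,4-dimethoxyphenyl gives a number 89 percentage points higher from compound 1 to compound 3 (beyond the scatter). The earlier step, a number 8 percentage points higher from compound 1 to compound 2 (within the scatter), showed only that one methoxy can give way to hydrogen on this ring without a change that can be told from the scatter, whereas exchanging the methoxy-bearing ring for the difluoro ring leaves a much weaker effect at the one concentration tested, with compound 3 at 12%. Nothing measured here gives a reason for this large shift.

Because compound 3 differs from the other two in both losing methoxy and gaining fluorine, the compounds shown cannot separate what each of those two changes contributes, and a plain phenyl or a 4-fluorophenyl on the same carbonyl carbon would be the kind of comparison that could. On these data alone, whether an amine or a hydroxyl on this ring could restore the stronger effect also remains open, as does how far the result holds in other cell lines.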